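This account rests on a few compounds, and the source may have more. Where it says the series, first, only, none or still open, it means among the compounds named here.

Compound 1 `NS(=O)(=O)c1ccc(N2N=C(c3ccc(Oc4ccccc4)cc3)CC2c2ccccc2F)cc1`: 36000 nM
Compound 2 `NS(=O)(=O)c1ccc(N2N=C(c3ccc(Oc4ccccc4)cc3)CC2c2ccc(Cl)cc2)cc1`: 9000 nM
Compound 3 `NS(=O)(=O)c1ccc(N2N=C(c3ccc(OCc4ccccc4)cc3)CC2c2ccccc2)cc1`: > 100000 nM

All three share one core and were tested in an ADME assay on MT4 cells (Homo sapiens) for cytotoxicity, read by MTT assay, with a stated time of 96 h; a lower number here means that less compound is tolerated, a higher number that more compound is tolerated. For compound 3 the reported value is a limit of the assay rather than a number (the limit of > 100000 nM in this assay, at which 1 of the 3 values shown sits), so compound 3 stands at the upper edge of everything shown, with no measured number of its own.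

Compound 4 `NS(=O)(=O)c1ccc(N2N=C(c3ccc(OCc4ccccc4)cc3)CC2c2ccc(F)cc2)cc1` differs from compound 3 by fluoro in place of hydrogen on an aromatic carbon. Within the data shown here, only one measured step touches the same ring: a 4.0-fold lower number from compound 1 to compound 2 (0.60 log units; beyond the scatter), where one halogen-bearing phenyl replaced another. That step was modest, and it compared two halogenated rings rather than adding a single fluoro to a bare phenyl, so it bears on the present change only loosely. On this evidence the expected movement in this assay is small, most likely none beyond the scatter, with a faint lean toward a lower number. Compound 4 is therefore expected to give about 100000 nM, in the range 40000 nM to 200000 nM. That estimate implies an expected step of a number no higher from compound 3 to compound 4 (the limit leaves the size open), and the result may again come back only as a limit.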

Compound 4, half-maximal cytotoxic concentration: > 100000 nM
Compound 4: a limit, no number; the forecaster's own chance of this, stated with the estimate: 60%; the middle value lies on the limit itself.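

In this assay compound 4 gives > 100000 nM as a limit and not a number. Compound 3 also rests on a limit, so the step between these two compounds cannot be read: the limit of > 100000 nM in this assay, at which 2 of the 4 values shown sit. The compounds shown leave open whether phenyl to 4-fluorophenyl changes this read-out at all.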